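A hydroxyethyl amide in place of the ethyl ester

The source may report more compounds than this note shows. Statements on the series, on what has been measured and on what is new or still open speak of the compounds shown alone.

Within the data shown here, compound 1 `CCOC(=O)c1c(C)oc2ncnc(Nc3cccc(Cl)c3)c12` is one of three compounds measured in a functional assay on MCF7 cells (Homo sapiens) for cytotoxicity, read by MTT assay, with a stated time of 72 h; on this read-out lower numbers stand for stronger inhibition and higher numbers for weaker inhibition. In this assay compound 1 gives > 1000000 nM, which is a limit of the assay rather than a number. Compound 2 `CCOC(=O)c1c(C)oc2ncnc(Nc3ccccc3)c12` carries hydrogen in place of chloro on an aromatic carbon; in this assay compound 2 gives 851000 nM, and an at least 1.1-fold lower number from compound 1 to compound 2 (0.07 log units; that floor lies within the scatter). Compound 3 `C#Cc1cccc(Nc2ncnc3oc(C)c(C(=O)OCC)c23)c1` carries ethynyl in place of chloro on an aromatic carbon. In this assay compound 3 gives > 1000000 nM, again a limit. Here (the limit of > 1000000 nM in this assay, at which 2 of the 3 values shown sit), so a step that the two limits leave unreadable from compound 1 to compound 3 and an at least 1.1-fold higher number from compound 2 to compound 3 (0.07 log units; that floor lies within the scatter).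

Compound 4 `Cc1oc2ncnc(Nc3cccc(Cl)c3)c2c1C(=O)NCCO` differs from compound 1 at another place: (2-hydroxyethyl)amino in place of ethoxy on a carbonyl carbon. Among the measured compounds shown here, every measured step changed the substituent on the aromatic carbon, and none moved the read-out beyond the scatter; no measured step touches the carbonyl carbon. The series gives no direct guide for this change, and compound 1 itself stands at a limit. The expected outcome is therefore a number no higher from compound 1 to compound 4 (the limit leaves the size open). Compound 4 is estimated at 1000000 nM, with a range from 300000 nM to 3000000 nM, and most likely again only a limit.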

Compound 4, half-maximal inhibitory concentration: > 1000000 nM
Compound 4: a limit, no number; the forecaster's own chance of this, stated with the estimate: 70%; the middle value sits exactly at the limit.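

Among these compounds, compound 1 and compound 4 both stand at a limit, so no step between them can be read: the limit of > 1000000 nM in this assay, at which 3 of the 4 values shown sit. The compounds shown leave open whether (2-hydroxyethyl)amino in place of ethoxy on a carbonyl carbon moves the read-out in this assay at all.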